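The source may hold more compounds than are shown below. What is called first, only, known or untested is meant among the compounds shown, and "the series" means these compounds.

Compound 1 `O=C(O)Cc1sc(C(c2ccccc2)c2ccccc2)nc1-c1ccc(C(F)(F)F)cc1` and compound 2 `O=C(O)Cc1sc(C(c2ccc(F)cc2)c2ccc(F)cc2)nc1-c1ccoc1` share a core that bears a carboxymethyl group. In an in vitro functional assay on HEK285-7 cells for antagonist activity at prostaglandin D2 receptor 2 (Homo sapiens), read by BRET and beta-arrestin recruitment (on this read-out lower numbers stand for smaller maximal responses and higher numbers for larger maximal responses), compound 1 gives 80% and compound 2 gives 80%, so compound 2 stands level with compound 1 within the scatter. Compound 3 `N#Cc1ccc(-c2nc(C(c3ccc(F)cc3)c3ccc(F)cc3)sc2CC(=O)O)cc1` differs from compound 2 in one place: 4-cyanophenyl in place of furan-3-yl on an aromatic carbon. Within the data shown here, no pair of measured compounds differs in one place, so no measured step guides this change. The expected step of no change at the digits printed from compound 2 to compound 3 (within the scatter) is none beyond the scatter. Compound 3 is therefore estimated at 80%, between 65% and 95%.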

Compound 3, largest response reached (reported as efficacy), in percent of the reference or control that the assay uses: 30%
Compound 3: middle estimate off by 50 percentage points, on the high side; measured number below the stated range.
By their numbers in this assay, from the lowest: compound 3; then compounds 1 and 2 (each within the scatter of the next).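

In this assay, the group on this aromatic carbon, next to the ring nitrogen, can change the result strongly: putting 4-cyanophenyl in place of furan-3-yl gives a number 50 percentage points lower from compound 2 to compound 3 (beyond the scatter) on an otherwise unchanged structure. The shared core alone therefore does not set the maximal response. Nothing measured here explains the drop. On these data alone, it remains open whether the six-membered ring or its nitrile accounts for the step. A plain phenyl ring, or a phenyl ring carrying an amine or a carboxylic acid in place of the nitrile, would help separate the two.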